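A few compounds are considered here, and "the series" means these few. Any claim that something is new, unique, unknown or untested is made for them only; others in the source may bear on it.

Compound 1 `CC(C)c1ccc(NC(=O)N2CCN(c3ncccc3Cl)CC2)cc1` gives 17.3 nM in a functional assay on HEK293 cells for antagonist activity at transient receptor potential cation channel subfamily V member 1 (Rattus norvegicus); on this read-out higher numbers stand for weaker inhibition and lower numbers for stronger inhibition. Compound 2 `CC(C)c1ccc(NC(=O)N2CCN(c3ncccc3Br)CC2)cc1` carries bromo in place of chloro on an aromatic carbon, and in this assay compound 2 gives 27.1 nM, a step of a 1.6-fold higher number from compound 1 to compound 2 (0.19 log units; within the scatter). Compound 3 `O=C(Nc1ccc(Cl)cc1)N1CCN(c2ncccc2Cl)CC1` differs from compound 1 by chloro in place of isopropyl on an aromatic carbon; in this assay compound 3 gives 2670 nM, a step of a 150-fold higher number from compound 1 to compound 3 (2.19 log units; beyond the scatter). Compound 4 `O=C(Nc1ccc(Br)cc1)N1CCN(c2ncccc2Cl)CC1`, not yet measured, carries bromo in place of chloro on an aromatic carbon. Among the measured compounds shown here, this is the same kind of change as the one from compound 1 to compound 2, though not the same: in compound 2 it sits on a six-membered aromatic ring with 1 nitrogen, ortho to a large group, two atoms from the ring nitrogen, whereas in compound 4 it sits on a six-membered aromatic ring of carbon only, para to a large group. Because a 1.6-fold higher number from compound 1 to compound 2 (0.19 log units; within the scatter) stayed within the scatter, the step from compound 3 to compound 4 is expected to be small as well, a 1.2-fold higher number from compound 3 to compound 4 (0.08 log units; within the scatter). Compound 4 is accordingly estimated at 3200 nM, between 1300 nM and 8000 nM.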

Compound 4, half-maximal inhibitory concentration: 1010 nM
For compound 4 the middle estimate is 3.2-fold (0.50 log units) above the measured one, and the stated range ends above it.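

The change from chloro to bromo did not carry over as one fixed step from one core to the other: the same change on two cores in this assay, a 1.6-fold higher number (0.19 log units; within the scatter) from compound 1 to compound 2 and a 2.6-fold lower number (0.42 log units; beyond the scatter) from compound 3 to compound 4, 4.1-fold (0.62 log units) apart, beyond the scatter of two such steps On the carbon-only ring, the change gives a 2.6-fold lower number from compound 3 to compound 4 (0.42 log units; beyond the scatter), yet bromo still falls far short of isopropyl, with a 58-fold higher number from compound 1 to compound 4 (1.77 log units; beyond the scatter). This single pair of steps does not show whether the difference comes from the position of the halogen or from the rest of each core, and it cannot predict the step on a further core.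

The compounds shown leave open how a tert-butyl or trifluoromethyl group would compare with isopropyl at the same place on the carbon-only ring. They also leave open whether iodo would extend the change from chloro to bromo.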